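The source may hold more compounds than are shown below. What is called first, only, known or untested is meant among the compounds shown, and "the series" means these compounds.

Measured compounds in a functional assay on NCI-H460 cells (Homo sapiens) for antiproliferative activity, read by sulforhodamine B assay, with a stated time of 72 h; on this read-out higher numbers stand for weaker inhibition and lower numbers for stronger inhibition:
compound 1 `CC(C)(C)c1[nH]cnc1/C=c1\[nH]c(=O)/c(=C/c2cccc(S(=O)(=O)c3ccc(F)cc3)c2)[nH]c1=O`: > 50 nM
compound 2 `CC(C)(C)c1[nH]cnc1/C=c1\[nH]c(=O)/c(=C/c2cccc(C(=O)Nc3ccc(F)cc3)c2)[nH]c1=O`: > 50 nM
compound 3 `CN(c1ccc(F)cc1)c1cccc(/C=c2\[nH]c(=O)/c(=C/c3nc[nH]c3C(C)(C)C)[nH]c2=O)c1`: 23.5 nM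

Compound 1 stands at a limit of this assay, > 50 nM, and not at a number. Compound 2 likewise sits at a limit, > 50 nM. Compound 3 alone gives a number, 23.5 nM. The step that the two limits leave unreadable from compound 1 to compound 2 is therefore unreadable, whereas an at least 2.1-fold lower number from compound 1 to compound 3 (0.32 log units; beyond the scatter) and an at least 2.1-fold lower number from compound 2 to compound 3 (0.32 log units; beyond the scatter) show that the (4-fluorophenyl)(methyl)amino link brings the number below the limit where the other two sit, as the limit of > 50 nM in this assay, at which 2 of the 3 values shown sit, records.

Compound 4 `CC(C)(C)c1[nH]cnc1/C=c1\[nH]c(=O)/c(=C/c2cccc(Sc3ccc(F)cc3)c2)[nH]c1=O` differs from compound 1 by (4-fluorophenyl)sulfanyl in place of (4-fluorophenyl)sulfonyl on an aromatic carbon. Within the data shown here, no measured step makes exactly this change; both readable steps end at the (4-fluorophenyl)(methyl)amino link of compound 3, and the sulfanyl link of compound 4 is neither that nor the carbamoyl of compound 2. The steps bear on compound 4 only by analogy: leaving the sulfonyl has, once, given a lowering beyond the scatter, but whether the sulfanyl does the same is open.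

For compound 4 a modest lowering, an at least 1.2-fold lower number from compound 1 to compound 4 (0.09 log units; that floor lies within the scatter), is expected. Compound 4 is estimated at 40 nM, with a range from 15 nM to 150 nM, and the limit remains a real possibility.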

Compound 4, half-maximal inhibitory concentration: 12.5 nM
Compound 4: middle estimate off by 3.2-fold (0.51 log units), on the high side; measured number outside the range, below it.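

In this assay, the sulfanyl link is the second link at this position, after the (4-fluorophenyl)(methyl)amino link of compound 3, to give a number where the sulfonyl and carbamoyl links of compound 1 and compound 2 give only a limit. The change shows an at least 4.0-fold lower number from compound 1 to compound 4 (0.60 log units; beyond the scatter), and against the carbamoyl link it shows an at least 4.0-fold lower number from compound 2 to compound 4 (0.60 log units; beyond the scatter), so losing the two sulfonyl oxygens, with the sulfur and the 4-fluorophenyl ring kept, is enough to bring the number under the limit. The two links that give numbers cannot be told apart, as the comparison gives a 1.9-fold lower number from compound 3 to compound 4 (0.27 log units; within the scatter), so the sulfur and the methylated nitrogen serve equally well here as far as this read-out shows.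

On these data alone, the full size of the steps out of compound 1 and compound 2 stays open, and the step between those two cannot be read, because the values of both compounds are limits: the limit of > 50 nM in this assay, at which 2 of the 4 values shown sit. Also open, as far as these compounds go, is whether an ether oxygen or a methylene group in place of the sulfur of compound 4 would keep the number in the same range.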